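The source may hold more compounds than are shown below. What is called first, only, known or untested is meant among the compounds shown, and "the series" means these compounds.

Measured compounds: compound 1 `CCCCCCCCCCCCNC(=O)[C@@H](NC(=O)c1cc2ccccc2n1C)[C@@H](C)O`, compound 2 `CCCCCCCCCCCCCCNC(=O)[C@@H](NC(=O)c1cccs1)[C@@H](C)O` and compound 3 `CCCCCCCCCCCCCCNC(=O)[C@@H](NC(=O)c1nccc2ccccc12)[C@@H](C)O`. In a functional assay on SW-620 cells (Homo sapiens) for cytotoxicity, read by MTT assay, with a stated time of 48 h (on this read-out higher numbers stand for weaker inhibition and lower numbers for stronger inhibition), compound 1 gives > 200000 nM, which is a limit of the assay. In this assay compound 2 gives 78400 nM. Compound 3 gives 30400 nM.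

Compound 3 gives the lowest of the two numbers in this assay; the step of a 2.6-fold lower number from compound 2 to compound 3 (0.41 log units; beyond the scatter) shows the gap to compound 2. The limit for compound 1 is the limit of > 200000 nM in this assay, at which 1 of the 3 values shown sits. Compound 4 `CCCCCCCCCCCCCCNC(=O)[C@@H](NC(=O)c1cc2ccccc2n1C)[C@@H](C)O` differs from compound 3 by 1-methyl-1H-indol-2-yl in place of isoquinolin-1-yl on a carbonyl carbon. Going by the values given here, only one measured step bears on a change at this carbonyl carbon, a 2.6-fold lower number from compound 2 to compound 3 (0.41 log units; beyond the scatter), which was modest. Compound 1 carries the same 1-methyl-1H-indol-2-yl group and reaches only a limit. Compound 4 is therefore expected to give a higher number, by about a 2.6-fold higher number from compound 3 to compound 4 (0.42 log units; beyond the scatter). Compound 4 is estimated at 80000 nM, with a range from 25000 nM to 250000 nM.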

Compound 4, half-maximal inhibitory concentration: 21500 nM
Beside the measured number, compound 4's estimate is 3.7-fold (0.57 log units) above it, outside the stated range (below it).
By their numbers in this assay, from the lowest: compounds 4 and 3 (each within the scatter of the next); then compound 2. At a limit, above all of these: compound 1.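

In this assay, 1-methyl-1H-indol-2-yl in place of isoquinolin-1-yl on the carbonyl carbon gives a 1.4-fold lower number from compound 3 to compound 4 (0.15 log units; within the scatter), so the two groups are not told apart, whereas 1-methyl-1H-indol-2-yl in place of thiophen-2-yl gives a 3.6-fold lower number from compound 2 to compound 4 (0.56 log units; beyond the scatter). With the 1-methyl-1H-indol-2-yl group kept, ethyl in place of hydrogen on the saturated chain gives an at least 9.3-fold lower number from compound 1 to compound 4 (0.96 log units; beyond the scatter). Compound 1 stands at a limit of the assay: the limit of > 200000 nM in this assay, at which 1 of the 4 values shown sits.

Open, going by these compounds, is how a group bearing an amine or a carboxylic acid on this carbonyl carbon would read. Also open, on these data alone, is how a chain longer than that of compound 4 would read.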